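The compounds below may be only part of what the source reports. "The series", "measured", "known", "first", "only" and "open" are said of these compounds alone.

Measured compounds:
compound 1, `COc1ccc(F)c([C@H]2CC[C@H](COc3cccc([C@@H](CC(=O)O)C4CC4)c3)CC2)c1` — 199 nM
compound 2, `COc1ccc(F)c([C@H]2CC[C@H](COc3cccc([C@H](C4CC4)[C@@H](C)C(=O)O)c3)CC2)c1` — 22 nM
compound 3, `COc1ccc(F)c([C@H]2CC[C@H](COc3cccc([C@H](C4CC4)[C@@H](F)C(=O)O)c3)CC2)c1` — 20 nM

All three were run in a functional assay on cells for agonist activity at Free fatty acid receptor 1 (Homo sapiens), read by HTRF and inositol phosphate accumulation, with a stated time of 90 min; a higher number here means that more compound is needed for the effect, a lower number that less compound is needed. Among the three numbers, compound 3 holds the lowest; its nearest neighbour, compound 2, sits within the scatter of it, while compound 1 lies furthest away, the gap being a 10-fold lower number from compound 1 to compound 3 (1.00 log units; beyond the scatter).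

Compound 4, `COc1ccc(F)c([C@H]2CC[C@H](COc3cccc([C@H](C4CC4)[C@](C)(F)C(=O)O)c3)CC2)c1`, is the compound that follows. It differs from compound 3 by methyl in place of hydrogen on a saturated chain carbon bound to a carbonyl carbon, a fluorine atom and a saturated chain carbon.

Among the measured compounds shown here, two measured steps bear on this change, since both put a group onto the same saturated chain carbon of compound 1: a methyl, giving a 9.0-fold lower number from compound 1 to compound 2 (0.96 log units; beyond the scatter), and a fluoro, giving a 10-fold lower number from compound 1 to compound 3 (1.00 log units; beyond the scatter). The third step, a 1.1-fold lower number from compound 2 to compound 3 (0.04 log units; within the scatter), shows that swapping one of those groups for the other changes nothing beyond the scatter. For the measured compounds named here, compound 4 now carries both groups on that carbon at once; no measured pair shows what a second group there does. The account therefore expects, for this assay, at most a small step, and estimates for compound 4 a shift of a 1.3-fold lower number from compound 3 to compound 4 (0.12 log units; within the scatter), with a value of about 15 nM, ranging from 5 nM to 50 nM.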

Compound 4, half-maximal effective concentration: 89 nM
For compound 4 the middle estimate is 5.9-fold (0.77 log units) below the measured one; the whole stated range lies below it.
By their numbers in this assay, from the lowest: compounds 3 and 2 (each within the scatter of the next); then compound 4; then compound 1.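

In this assay, the effect of methyl in place of hydrogen on this saturated chain carbon turns out to depend on what else the carbon carries: the same change on two cores in this assay, a 9.0-fold lower number (0.96 log units; beyond the scatter) from compound 1 to compound 2 and a 4.5-fold higher number (0.65 log units; beyond the scatter) from compound 3 to compound 4, 40-fold (1.60 log units) apart, beyond the scatter of two such steps. A second group here gives back part of what a single group gained, whichever of the two is taken as the starting point: there is a 4.5-fold higher number from compound 3 to compound 4 (0.65 log units; beyond the scatter), and also a 4.0-fold higher number from compound 2 to compound 4 (0.61 log units; beyond the scatter). Even so, the carbon bearing both groups keeps an advantage over the one bearing neither, with a 2.2-fold lower number from compound 1 to compound 4 (0.35 log units; beyond the scatter), so the two groups together are better than none but worse than either one alone.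

The compounds shown cannot say whether this reversal belongs to the pairing of methyl and fluoro or would come with any second group on this carbon, such as a second fluoro, or a hydroxyl alongside the methyl. Also open, as far as these compounds go, is what the opposite arrangement of methyl and fluoro at this carbon would give, since compound 4 shows only one of the two.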